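This account rests on a few compounds, and the source may have more. Where it says the series, first, only, none or still open, it means among the compounds named here.

Within the data shown here, compound 1, with the structure `COc1ccc(S(=O)(=O)c2cnc3ccc(C)cc3c2N2CCC(C)CC2)cc1Cl`, stands highest of the two numbers so far in an assay on isolated protein for displacement of a labelled ligand from metabotropic glutamate receptor 5 (Homo sapiens), with a stated time of 60 min, tested at 1 uM (on this read-out lower numbers stand for less inhibition and higher numbers for more inhibition at the one concentration tested (going by the name of the read-out)), where compound 1 gives 93%. Its nearest neighbour is compound 2, `COc1ccc(S(=O)(=O)c2cnc3ccc(Cl)cc3c2N2CCC(C)CC2)cc1Cl`, which in this assay gives 46%; that pair forms the step of a number 47 percentage points lower from compound 1 to compound 2 (beyond the scatter), a chloro in place of methyl on an aromatic carbon of the shared core. The unmeasured compound 3, `Cc1ccc2ncc(S(=O)(=O)c3ccc(F)c(Cl)c3)c(N3CCC(C)CC3)c2c1`, differs from compound 1 elsewhere: fluoro in place of methoxy on an aromatic carbon. Among the measured compounds shown here, the one measured step concerns a different position and a different exchange, so it does not bear directly on this change; the only guidance is that compound 1 sits near the top of the read-out, leaving little room upward. Compound 3 is therefore expected to stay close to compound 1, with a step of a number 13 percentage points lower from compound 1 to compound 3 (beyond the scatter), and its value in this assay is estimated at 80%, in a range from 55% to 95%.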

Compound 3, a percentage reported as inhibition, at one concentration (the size of the read-out at that concentration, not a potency): 93%
Estimate against measurement, compound 3: 13 percentage points below; low and high end bracket the measured number.
By their numbers in this assay, from the lowest: compound 2; then compounds 1 and 3 (each within the scatter of the next).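

Exchanging methoxy for fluoro on this aromatic carbon, ortho to a chloro group and para to a large group, gives no change at the digits printed from compound 1 to compound 3 (within the scatter) in this assay. This place therefore accepts the change from 3-chloro-4-methoxyphenyl to 3-chloro-4-fluorophenyl, with one heavy atom fewer and the hydrogen-bond acceptor gone, and the read-out stays high; the earlier compounds had shown only a large response to a change elsewhere on the shared core. Nothing available explains why this place and that other one differ in this way.

Going by these compounds, it remains open whether an amine, a carboxylic acid or a longer chain such as ethoxy would hold the read-out at this place. On these data alone, it is also open whether fluoro would do the same alongside the chloro that compound 2 carries, where compound 2 gives 46% with methoxy.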